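Methyl on the chain carbon of compound 3

A few compounds are considered here, and "the series" means these few. Any claim that something is new, unique, unknown or untested is made for them only; others in the source may bear on it.

Measured in a functional assay on the whole organism for agonist activity, with Mus musculus as the target; a higher number here means that more compound is needed for the effect, a lower number that less compound is needed:
- compound 1 `CC(=O)N(C)CC#CCn1cncc1C`: 5.4 mg/kg
- compound 2 `COC(=O)NCC#CCn1cncc1C`: > 100 mg/kg (a limit of the assay, not a number)
- compound 3 `COC(=O)N(C)CC#CCn1cncc1C`: 4.5 mg/kg

For the measured compounds named here, compound 3 at 4.5 mg/kg and compound 1 at 5.4 mg/kg lie within the scatter of each other, and together they form the low end of the numbers so far. Compound 4 `COC(=O)N(C)C(C)C#CCn1cncc1C` carries methyl in place of hydrogen on a saturated chain carbon bound to an amide-type nitrogen and a triple-bonded carbon.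

Going by the values given here, no measured step touches this carbon. Methoxy in place of methyl on a carbonyl carbon gave a 1.2-fold lower number from compound 1 to compound 3 (0.08 log units; within the scatter). Methyl in place of hydrogen on an amide-type nitrogen gave an at least 22-fold lower number from compound 2 to compound 3 (1.34 log units; beyond the scatter), so a single methyl elsewhere in compound 3 can matter greatly. With compound 3 already at 4.5 mg/kg, a move to a higher number is the more likely outcome, though the direction remains uncertain. The expected step is a 4.0-fold higher number from compound 3 to compound 4 (0.60 log units; beyond the scatter). Compound 4 is estimated at 18 mg/kg, with an expected range of 4 mg/kg to 90 mg/kg.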

Compound 4, dose for half-maximal effect: 97 mg/kg
Beside the measured number, compound 4's estimate is 5.4-fold (0.73 log units) below it; measured number above the stated range.
By their numbers in this assay, from the lowest: compounds 3 and 1 (each within the scatter of the next); then compound 4. At a limit, above all of these: compound 2.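

In this assay, the saturated chain carbon bound to an amide-type nitrogen and a triple-bonded carbon does not tolerate added bulk freely: methyl in place of hydrogen there gives a 22-fold higher number from compound 3 to compound 4 (1.33 log units; beyond the scatter). For the compounds shown here, the earlier large steps all turned on the amide-type nitrogen, so this is the first sign that the chain itself responds just as strongly, and to a single added methyl. Compound 2 remains a limit of the assay, not a number: the limit of > 100 mg/kg in this assay, at which 1 of the 4 values shown sits.

Only hydrogen and methyl are shown at this carbon, so it stays open whether ethyl, hydroxyl or fluorine would raise the number to the same degree. Also open, from the compounds shown here alone, is whether the same methyl has a comparable effect on the acetyl amide of compound 1.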